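Fluorine for chlorine on a shifted amide: expected loss

This account rests on a few compounds, and the source may have more. Where it says the series, first, only, none or still open, it means among the compounds named here.

Compound 1 `O=C(NNC(=O)c1cccc(Cl)c1)c1ccc(NS(=O)(=O)c2cnc(O)nc2O)cc1` and compound 3 `O=C(NNC(=O)c1ccccc1NS(=O)(=O)c1cnc(O)nc1O)c1cccc(Cl)c1` share the same atoms joined differently; the difference between the two cores is not broken down here. In a functional assay on SGC-7901 cells (Homo sapiens) for antiproliferative activity, read by MTT assay, with a stated time of 24 h (a higher number here means a weaker inhibitor, a lower number a stronger inhibitor), compound 1 gives 8610 nM, while compound 3 gives 1820 nM. Compound 2 `O=C(NNC(=O)c1ccccc1F)c1ccc(NS(=O)(=O)c2cnc(O)nc2O)cc1` carries the change (2-fluorophenyl in place of 3-chlorophenyl on a carbonyl carbon). In this assay compound 2 reaches only a limit, > 20000 nM, which is the limit of > 20000 nM in this assay, at which 1 of the 3 values shown sits. The step of an at least 2.3-fold higher number from compound 1 to compound 2 (0.36 log units; beyond the scatter) therefore marks a weakening. Compound 4 `O=C(NNC(=O)c1ccccc1NS(=O)(=O)c1cnc(O)nc1O)c1ccccc1F` carries the same change, (2-fluorophenyl in place of 3-chlorophenyl on a carbonyl carbon), on the core of compound 3. Since compound 3 gives 1820 nM, a weakening of comparable size is expected, a 3.8-fold higher number from compound 3 to compound 4 (0.59 log units; beyond the scatter). That compound 2 reached only a limit leaves the upper end of this expectation open. Compound 4 is estimated at 7000 nM in this assay.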

Compound 4, half-maximal inhibitory concentration: > 20000 nM
Compound 4 was reported as a limit (the forecaster's own chance of this, stated with the estimate: 25%); middle value at least 2.8-fold (0.45 log units) from the limit.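

In this assay, the change from 3-chlorophenyl to 2-fluorophenyl also weakens the second core, with an at least 10-fold higher number from compound 3 to compound 4 (1.04 log units; beyond the scatter). Compound 4 reaches only a limit of the assay, > 20000 nM. The change therefore goes in the same direction on both cores, but this does not show that its size carries over from one core to the other: the same change on two cores in this assay, an at least 2.3-fold higher number (0.36 log units; beyond the scatter) from compound 1 to compound 2 and an at least 10-fold higher number (1.04 log units; beyond the scatter) from compound 3 to compound 4; the limit leaves it open whether they differ

Both the halogen and its place on the ring change together, so the compounds shown cannot tell which of the two accounts for the loss. From the compounds shown here alone, whether a 2-chlorophenyl or a 3-fluorophenyl group on the same carbonyl carbon would keep the activity of compound 3 remains open.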